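This account rests on a few compounds, and the source may have more. Where it says the series, first, only, none or still open, it means among the compounds named here.

In a functional assay on HCT-116 cells (Homo sapiens) for cytotoxicity, read by MTT assay, with a stated time of 72 h (on this read-out lower numbers stand for stronger inhibition and higher numbers for weaker inhibition), compound 1 `Nc1ccc(Nc2c(C(=O)NCc3ccc(F)cc3)nc(Br)c3cccnc23)cc1` gives 10000 nM and compound 3 `N[C@H]1CC[C@H](Nc2c(C(=O)NCc3ccc(F)cc3)nc(Br)c3cccnc23)CC1` gives 7000 nM, so compound 3 stands within the scatter of compound 1. Compound 2 `CN(C)CCCNc1c(C(=O)NCc2ccc(F)cc2)nc(Br)c2cccnc12` reads > 10000 nM, which is a limit of the assay. Compound 4 `O=C(NCc1ccc(F)cc1)c1nc(Br)c2cccnc2c1NCCO` carries 2-hydroxyethyl in place of 4-aminocyclohexyl on a nitrogen on an aromatic ring. The measured swaps on that nitrogen are a 1.4-fold lower number from compound 1 to compound 3 (0.15 log units; within the scatter), an at least 1.4-fold lower number from compound 2 to compound 3 (0.15 log units; that floor lies within the scatter) and a number no lower from compound 1 to compound 2 (the limit leaves the size open). None is shown beyond the scatter, so no step beyond it is expected in this assay, though a bare limit reading remains possible. The expected change is a 1.4-fold higher number from compound 3 to compound 4 (0.15 log units; within the scatter). For compound 4 the estimated value is 10000 nM, with an expected range of 5000 nM to 20000 nM.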

Compound 4, half-maximal inhibitory concentration: > 20000 nM
Compound 4 ended at the assay's limit (the forecaster's own chance of this, stated with the estimate: 45%); middle value at least 2.0-fold (0.30 log units) from the limit.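

In this assay, this nitrogen now shows its first step beyond the scatter, with 2-hydroxyethyl replacing 4-aminocyclohexyl: an at least 2.8-fold higher number from compound 3 to compound 4 (0.45 log units; beyond the scatter). Against 4-aminophenyl the reading is weaker, an at least 2.0-fold higher number from compound 1 to compound 4 (0.30 log units; that floor lies within the scatter), and the step between compound 2 and compound 4 cannot be read, since both values are limits. The value of compound 4 is a limit, not a number: the limit of > 20000 nM in this assay, at which 1 of the 4 values shown sits.

Going by these compounds, the true size of the step therefore stays open. Also open, on these data alone, is whether the ring or the amine of 4-aminocyclohexyl matters more, which a 2-aminoethyl chain and an unsubstituted cyclohexyl would separate.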